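A few compounds are considered here, and "the series" means these few. Any claim that something is new, unique, unknown or untested is made for them only; others in the source may bear on it.

Measured so far in a functional assay on cells for antagonist activity at prostaglandin D2 receptor 2 (Homo sapiens), read by flow cytometry, with a stated time of 10 min; on this read-out higher numbers stand for weaker inhibition and lower numbers for stronger inhibition:

Compound 1 `CN(C)S(=O)(=O)c1ccc(F)c(C#Cc2cc(Cl)ccc2OCC(=O)O)c1` gives 23 nM.
Compound 2 `Cc1ccc(S(=O)(=O)N(C)C)cc1C#Cc1cc(Cl)ccc1OCC(=O)O` gives 77 nM.
Compound 3 `CS(=O)(=O)c1ccc(F)c(C#Cc2cc(Cl)ccc2OCC(=O)O)c1` gives 95 nM.
Compound 4 `Cc1ccc(S(C)(=O)=O)cc1C#Cc1cc(Cl)ccc1OCC(=O)O` is not yet measured.

Compound 1 and compound 2 differ in one place, (methyl in place of fluoro on an aromatic carbon). On this read-out the change gave a 3.3-fold higher number from compound 1 to compound 2 (0.52 log units; beyond the scatter). The two cores, that of compound 1 and that of compound 3, differ in one place as well, (methyl in place of dimethylamino on a sulfonyl sulfur), and on its own this difference gave a 4.1-fold higher number from compound 1 to compound 3 (0.62 log units; beyond the scatter). The values of compound 2 and compound 3 in this assay lie within the scatter of each other.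

Compound 4 differs from compound 3 by methyl in place of fluoro on an aromatic carbon. Among the measured compounds shown here, this is the same kind of change as the one from compound 1 to compound 2, but not the same: there the methyl enters para to a dimethylsulfamoyl group (6 heavy atoms), here para to a methylsulfonyl group (4 heavy atoms). For the measured compounds named here, only one example of the change is measured, and on the other core, so the expectation rests on that single step. Going by the values given here, the step in this assay from compound 3 to compound 4 is expected to be a 3.2-fold higher number from compound 3 to compound 4 (0.50 log units; beyond the scatter), of about the size seen in a 3.3-fold higher number from compound 1 to compound 2 (0.52 log units; beyond the scatter), because a 3.3-fold higher number from compound 1 to compound 2 (0.52 log units; beyond the scatter) is the only measured instance of this kind of change. Compound 4 is therefore estimated at 300 nM, with the plausible range running from 120 nM to 750 nM.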

Compound 4, half-maximal inhibitory concentration: 64 nM
Beside the measured number, compound 4's estimate is 4.7-fold (0.67 log units) above it; measured number outside the range, below it.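

In this assay, methyl in place of fluoro on an aromatic carbon gives a 1.5-fold lower number from compound 3 to compound 4 (0.17 log units; within the scatter), so the step seen on the core of compound 1 does not carry over to the core bearing the methylsulfonyl group: the same change on two cores in this assay, a 3.3-fold higher number (0.52 log units; beyond the scatter) from compound 1 to compound 2 and a 1.5-fold lower number (0.17 log units; within the scatter) from compound 3 to compound 4, 5.0-fold (0.70 log units) apart, beyond the scatter of two such steps

The same holds when the set of four compounds is read the other way, with methyl in place of dimethylamino on a sulfonyl sulfur giving a 1.2-fold lower number from compound 2 to compound 4 (0.08 log units; within the scatter): the same change on two cores in this assay, a 4.1-fold higher number (0.62 log units; beyond the scatter) from compound 1 to compound 3 and a 1.2-fold lower number (0.08 log units; within the scatter) from compound 2 to compound 4, 5.0-fold (0.70 log units) apart, beyond the scatter of two such steps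

Both comparisons rest on the same four compounds, so they show that the two changes do not add up here and that a step measured on one of these cores is a poor guide to the other, but they do not show why, nor which behaviour would be the more usual one across the series.

Open, on these data alone, is whether other groups on that aromatic carbon, such as methoxy or a nitrile, would also depend on the group at the sulfonyl sulfur. Equally open, as far as these compounds go, is whether a different group on the sulfur, such as ethyl or a cyclic amine like morpholine, would follow the dimethylamino compounds or the methyl compounds.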